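The source may report more compounds than this note shows. Statements on the series, on what has been measured and on what is new or still open speak of the compounds shown alone.

Compound 1 `CN1CCN(c2ccc(Nc3ncc(Cl)c(Nc4ccccc4)n3)nc2)CC1`: > 100000 nM
Compound 2 `COc1cccc(CNc2nc(Nc3ccc(N4CCN(C)CC4)cn3)ncc2Cl)c1`: 73400 nM

Going by the values given here, in a functional assay on Jurkat cells (Homo sapiens) for inhibition, read by CCK-8 assay, with a stated time of 48 h (on this read-out higher numbers stand for weaker inhibition of growth and lower numbers for stronger inhibition of growth), compound 2 gives 73400 nM, the only exact number so far. Compound 1 gives > 100000 nM, which is a limit of the assay. Compound 3 `COc1ccccc1CNc1nc(Nc2ccc(N3CCN(C)CC3)cn2)ncc1Cl` differs from compound 2 as follows: 2-methoxyphenyl in place of 3-methoxyphenyl on a saturated chain carbon bound to a nitrogen on an aromatic ring. Among the compounds with values here, the one measured step, an at least 1.3-fold lower number from compound 1 to compound 2 (0.13 log units; that floor lies within the scatter), involves a different change, and no measured step moves the methoxy group. No step beyond the scatter is therefore expected in this assay. The expected step is a 1.1-fold lower number from compound 2 to compound 3 (0.05 log units; within the scatter). For compound 3 the estimate is 65000 nM, with an expected range from 28000 nM to 100000 nM.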

Compound 3, concentration for 50% growth inhibition: 10800 nM
For compound 3 the middle estimate is 6.0-fold (0.78 log units) above the measured one, outside the stated range (below it).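

In this assay, 2-methoxyphenyl in place of 3-methoxyphenyl on a saturated chain carbon bound to a nitrogen on an aromatic ring gives a 6.8-fold lower number from compound 2 to compound 3 (0.83 log units; beyond the scatter), so the place of the methoxy group alone matters here, with the same atoms joined differently. Set against phenyl, 2-methoxybenzyl gives an at least 9.2-fold lower number from compound 1 to compound 3 (0.96 log units; beyond the scatter), whereas the floor of the 3-methoxybenzyl step lay within the scatter. For compound 1 the value > 100000 nM is a limit of the assay and not a number.

From the compounds shown here alone, whether this effect belongs to the methoxy group itself stays open, since 2-chlorophenyl or 2-hydroxyphenyl could be set in its place. Going by these compounds, how 4-methoxyphenyl or an unsubstituted benzyl would compare is also open.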